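The source may report more compounds than this note shows. Statements on the series, on what has been measured and on what is new or still open speak of the compounds shown alone.

Working notes, values so far from a functional assay on MDA-MB-231 cells (Homo sapiens), read by microscopy and transwell migration, with a stated time of 24 h (a lower number here means a stronger inhibitor, a higher number a weaker inhibitor), as the only read-out:

- Compound 1 `O=C(Nc1nc(-c2cccc(Cl)c2)cs1)c1ccccc1` gives 123 nM
- Compound 2 `O=C(Nc1nc(-c2cc(C(F)(F)F)cc(C(F)(F)F)c2)cs1)c1ccccc1` gives 336 nM
- Compound 3 `COc1cc(-c2csc(NC(=O)c3ccccc3)n2)cc(OC)c1OC` gives > 50000 nM

For compound 3 the entry > 50000 nM is a limit of the assay and not a number. Going by these compounds, compound 3 therefore stands apart from compound 1 and compound 2, which both return measured numbers, and its exact place on the scale stays open.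

Compound 4 `COc1cccc(C(=O)Nc2nc(-c3cc(OC)c(OC)c(OC)c3)cs2)c1` is the next step from compound 3, with methoxy in place of hydrogen on an aromatic carbon, meta to a large group, and the counted change is methoxy in place of hydrogen on an aromatic carbon in full. The same difference reads phenyl to 3-methoxyphenyl.

Going by the values given here, no two measured compounds differ in one place only, so no measured step gives a size for this change in this assay as it stands. With compound 3 at the limit > 50000 nM as the starting point, the expectation is no step beyond the scatter, or a small one toward stronger inhibition, and a further limit is quite possible. The expected move is an at least 1.2-fold lower number from compound 3 to compound 4 (0.09 log units; that floor lies within the scatter) as estimated here. Compound 4 is estimated at 40000 nM with an expected range from 4000 nM to 100000 nM in this reading.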

Compound 4, half-maximal inhibitory concentration: 14000 nM
Compound 4: middle estimate off by 2.9-fold (0.46 log units), on the high side; low and high end bracket the measured number.
By their numbers in this assay, from the lowest: compound 1; then compound 2; then compound 4. At a limit, above all of these: compound 3.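

In this assay, going by these compounds alone, the change from phenyl to 3-methoxyphenyl gives the first step that can be read between two compounds differing in one place: an at least 3.5-fold lower number from compound 3 to compound 4 (0.55 log units; beyond the scatter). Compound 1, compound 2 and compound 3 all carry the plain phenyl, so they say nothing about this ring; compound 4, at 14000 nM, shows that a methoxy in this place brings a measured number and a move beyond the scatter. Compound 3 supplies a limit and not a number, so the step is a floor and not a full size: the limit of > 50000 nM in this assay, at which 1 of the 4 values shown sits.

Going by these compounds, whether the same methoxy gives a comparable step on the cores of compound 1 and compound 2 stays open, as does what happens when it is moved to another carbon of the same ring. Also open, on these data alone, is whether an amine, a carboxylic acid or a longer chain such as ethoxy in this place would move the number as methoxy does, or in the other direction.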